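The source may hold more compounds than are shown below. What is called first, only, known or untested is meant among the compounds shown, and "the series" means these compounds.

Measured so far:
compound 1 `CCCCNc1cc(-c2ccccc2)nc2cc(OC)cc(OC)c12`: 4460 nM
compound 2 `COc1cc(OC)c2c(NC3CCCCC3)cc(-c3ccccc3)nc2c1`: 3160 nM

In a functional assay on HepG2 cells (Homo sapiens) for inhibition, read by MTT assay, with a stated time of 72 h (a higher number here means a weaker inhibitor, a lower number a stronger inhibitor), compound 1 gives 4460 nM and compound 2 gives 3160 nM. Within the data shown here, the only step among the measured compounds is a 1.4-fold lower number from compound 1 to compound 2 (0.15 log units; within the scatter), which lies within the scatter, so compound 2 cannot be set apart from compound 1 on these numbers; the two stand together.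

Compound 3 `COc1cc(OC)c2c(NCc3ccccc3)cc(-c3ccccc3)nc2c1` is reached from compound 2 by one change: benzyl in place of cyclohexyl on a nitrogen on an aromatic ring. Among the measured compounds shown here, the one measured step that bears on this place is a 1.4-fold lower number from compound 1 to compound 2 (0.15 log units; within the scatter), where the group on the same nitrogen was also exchanged, and that step stayed within the scatter. For the measured compounds named here, there is no measured pair that shows what an aromatic ring in place of the non-aromatic one does here, so the expectation rests only on that single step.

On that basis, no step beyond the scatter is expected in this assay from compound 2 to compound 3, that is, a step of about a 1.1-fold lower number from compound 2 to compound 3 (0.02 log units; within the scatter). Compound 3 is therefore estimated at 3000 nM, with a range from 1200 nM to 8000 nM.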

Compound 3, half-maximal inhibitory concentration: 10900 nM
Estimate against measurement, compound 3: 3.6-fold (0.56 log units) below, and the stated range ends below it.
By their numbers in this assay, from the lowest: compounds 2 and 1 (each within the scatter of the next); then compound 3.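

In this assay, the group on this nitrogen now makes a readable difference: butyl and cyclohexyl could not be told apart, but benzyl gives a 3.4-fold higher number from compound 2 to compound 3 (0.54 log units; beyond the scatter) and a 2.4-fold higher number from compound 1 to compound 3 (0.39 log units; beyond the scatter), which leaves compound 3 as the weakest inhibitor of the three. Both steps are modest, yet both lie beyond the scatter, so exchanges at this place are not all equivalent, and having a six-membered ring of carbon there does not by itself settle the result, since cyclohexyl carries a non-aromatic ring and benzyl an aromatic one. Nothing measured here offers a reason for this shift.

These three compounds cannot show whether the step follows from the aromatic ring itself or from the way that ring is joined to the nitrogen, and a phenyl group placed directly on the nitrogen or a longer phenylethyl chain would help to separate the two. On these data alone, how a pyridylmethyl group or a chain ending in a morpholine would behave on the same nitrogen also remains open.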